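Swapping Bromine for Chlorine in Weak Growth Inhibitors

This account rests on a few compounds, and the source may have more. Where it says the series, first, only, none or still open, it means among the compounds named here.

In a functional assay on HeLa cells (Homo sapiens) for inhibition, read by sulforhodamine B assay, with a stated time of 48 h (a lower number here means a stronger inhibitor of growth, a higher number a weaker inhibitor of growth), the three measured compounds give the following numbers.

compound 1, `COC(=O)[C@@]1(C)CCC=C2[C@@H]1CC[C@@H](C)[C@]2(C)Cc1c[nH]c2ccc(Br)cc12`, gives 10000 nM
compound 2, `COC(=O)[C@@]1(C)CCC=C2[C@@H]1CC[C@@H](C)[C@]2(C)Cc1c[nH]c2ccc(Cl)cc12`, gives 11000 nM
compound 3, `COC(=O)[C@@]1(C)CCC=C2[C@@H]1CC[C@@H](C)[C@]2(C)Cc1c(C)[nH]c2c(Br)cccc12`, gives 22000 nM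

All three are weak inhibitors of growth. Compound 2 differs from compound 1 in a single place: chloro in place of bromo on an aromatic carbon. That change made a 1.1-fold higher number from compound 1 to compound 2 (0.04 log units; within the scatter). Compound 3 is built on a different core from compound 1; the difference between the two cores is not broken down here. Compound 3 gives the highest of the three numbers, but its gap to compound 2 is within the scatter, while its gap to compound 1 is beyond it.

Compound 4, `COC(=O)[C@@]1(C)CCC=C2[C@@H]1CC[C@@H](C)[C@]2(C)Cc1c(C)[nH]c2c(Cl)cccc12`, has not been measured. It differs from compound 3 in the same way that compound 2 differs from compound 1: chloro in place of bromo on an aromatic carbon. The surroundings are not identical, though: in compound 1 the group sits meta to a fused ring and para to a fused ring, whereas in compound 3 it sits ortho to a fused ring and meta to a fused ring, so this is the same kind of change rather than the same change. Because a 1.1-fold higher number from compound 1 to compound 2 (0.04 log units; within the scatter) stayed within the scatter, a similarly small step is expected here: a 1.1-fold higher number from compound 3 to compound 4 (0.04 log units; within the scatter). Compound 4 is therefore estimated at 24000 nM, with a likely range from 11000 nM to 50000 nM. This rests on a single measured pair, so the range is kept wide.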

Compound 4, concentration for 50% growth inhibition: 17000 nM
Beside the measured number, compound 4's estimate is 1.4-fold (0.15 log units) above it, and the stated range covers the measured number.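

In this assay, chloro in place of bromo on an aromatic carbon of the core of compound 3 gives a 1.3-fold lower number from compound 3 to compound 4 (0.11 log units; within the scatter), so on this core, as on the core of compound 1, the swap leaves no change that can be told apart from the noise of repeated measurements. Set side by side, the two steps agree, and the swap carries over between these two cores without a detectable difference: the same change on two cores in this assay, a 1.1-fold higher number (0.04 log units; within the scatter) from compound 1 to compound 2 and a 1.3-fold lower number (0.11 log units; within the scatter) from compound 3 to compound 4, 1.4-fold (0.15 log units) apart, within the scatter of two such steps. Among the compounds shown here, this does not show that the two halogens are interchangeable in general, since it rests on only two pairs in one assay, with the halogen at a different place on each core, all among weak inhibitors of growth, and a small real effect could be hidden in the scatter.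

The compounds shown leave open whether a different group at these places, such as fluoro, methoxy, a nitrile or an amine, would move the number further than either halogen does. They also leave open whether changes elsewhere in the molecule, such as a carboxylic acid in place of the methyl ester, would give a stronger inhibitor of growth.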